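Hydroxy on the Shared Core and a Chlorophenyl Swap

This account rests on a few compounds, and the source may have more. Where it says the series, first, only, none or still open, it means among the compounds named here.

Compound 1 `CN(C)c1ccc(-c2ccc(-c3ccc(-c4nc5ccccc5[nH]4)cc3)cc2)cc1`: 100000 nM
Compound 2 `Clc1cccc(-c2ccc(-c3ccc(-c4nc5ccccc5[nH]4)cc3)cc2)c1`: 100000 nM
Compound 3 `CN(C)c1ccc(-c2ccc(-c3ccc(-c4nc5c(O)cccc5[nH]4)cc3)cc2)cc1`: 8250 nM

In a functional assay on HOP-62 cells (Homo sapiens) for inhibition, read by sulforhodamine B assay (a lower number here means a stronger inhibitor of growth, a higher number a weaker inhibitor of growth), compound 1 gives 100000 nM and compound 2 gives 100000 nM. The two differ by 3-chlorophenyl in place of 4-(dimethylamino)phenyl on an aromatic carbon, and that change made no change at the digits printed from compound 1 to compound 2 (within the scatter). Compound 3 differs from compound 1 by hydroxy in place of hydrogen on an aromatic carbon, which made a 12-fold lower number from compound 1 to compound 3 (1.08 log units; beyond the scatter). Compound 4 `Oc1cccc2[nH]c(-c3ccc(-c4ccc(-c5cccc(Cl)c5)cc4)cc3)nc12` has not yet been measured in this assay; it differs from compound 3 by 3-chlorophenyl in place of 4-(dimethylamino)phenyl on an aromatic carbon, the same change as that from compound 1 to compound 2, at the same place. Because that earlier change made no change at the digits printed from compound 1 to compound 2 (within the scatter), the step from compound 3 to compound 4 is expected to be small, about a 1.2-fold higher number from compound 3 to compound 4 (0.08 log units; within the scatter). Compound 4 is therefore estimated at 10000 nM, with a range from 3000 nM to 40000 nM.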

Compound 4, concentration for 50% growth inhibition: 2260 nM
For compound 4 the middle estimate is 4.4-fold (0.65 log units) above the measured one; the measured number lies below the stated range.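

In this assay, the swap to 3-chlorophenyl on the core carrying hydroxy gave a 3.7-fold lower number from compound 3 to compound 4 (0.56 log units; beyond the scatter), so the result seen without hydroxy did not carry over: the same change on two cores in this assay, no change at the digits printed (within the scatter) from compound 1 to compound 2 and a 3.7-fold lower number (0.56 log units; beyond the scatter) from compound 3 to compound 4, 3.7-fold (0.56 log units) apart, beyond the scatter of two such steps

Adding hydroxy to the core of compound 2 gave a 44-fold lower number from compound 2 to compound 4 (1.65 log units; beyond the scatter), and this step also differs in size from the earlier hydroxy step: the same change on two cores in this assay, a 12-fold lower number (1.08 log units; beyond the scatter) from compound 1 to compound 3 and a 44-fold lower number (1.65 log units; beyond the scatter) from compound 2 to compound 4, 3.7-fold (0.56 log units) apart, beyond the scatter of two such steps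

Both gaps come from the same four compounds, so they are one finding: in this set, the effects of the two changes do not simply add up, though the data do not show why or whether this holds for other groups.

The compounds shown leave open whether a methoxy group or an amine in place of the hydroxy would also lower the number. They also leave open how a pyridine ring in place of the 3-chlorophenyl would behave on either core.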